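The source may hold more compounds than are shown below. What is called first, only, known or untested is meant among the compounds shown, and "the series" means these compounds.

Measured so far: compound 1 `N#CSCN1C(=O)c2ccccc2C1=O` gives 48100 nM in a functional assay on MCF7 cells (Homo sapiens) for cytotoxicity, read by MTT assay, with a stated time of 72 h; a lower number here means a stronger inhibitor of growth, a higher number a weaker inhibitor of growth; compound 2 `N#C[Se]CN1C(=O)c2ccccc2C1=O` gives 15400 nM; compound 3 `Cc1noc(C)c1CSC#N` gives 4800 nM.

The step from compound 1 to compound 2 is a group of 3 heavy atoms (1 carbon, 1 nitrogen, 1 selenium; no ring) in place of a group of 3 heavy atoms (1 carbon, 1 nitrogen, 1 sulfur; no ring), on a saturated chain carbon bound to an amide-type nitrogen in a ring, and it gave a 3.1-fold lower number from compound 1 to compound 2 (0.49 log units; beyond the scatter). Compound 4 `Cc1noc(C)c1C[Se]C#N`, not yet measured, stands to compound 3 as compound 2 stands to compound 1: the change is a group of 3 heavy atoms (1 carbon, 1 nitrogen, 1 selenium; no ring) in place of a group of 3 heavy atoms (1 carbon, 1 nitrogen, 1 sulfur; no ring), on a saturated chain carbon bound to an aromatic carbon. It is the same kind of change, not the same one, since in compound 1 the place is a saturated chain carbon bound to an amide-type nitrogen in a ring, while in compound 3 it is a saturated chain carbon bound to an aromatic carbon. The difference between the two cores is not broken down here. Compound 3 already has the lowest number of the three. A step of about the earlier size is expected from compound 3 to compound 4, a 2.7-fold lower number from compound 3 to compound 4 (0.43 log units; beyond the scatter), resting on the step from compound 1 to compound 2, a 3.1-fold lower number from compound 1 to compound 2 (0.49 log units; beyond the scatter), though the different surroundings leave this uncertain. Compound 4 is therefore estimated at 1800 nM in this assay, plausibly between 600 nM and 5500 nM.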

Compound 4, concentration for 50% growth inhibition: 2200 nM
Beside the measured number, compound 4's estimate is 1.2-fold (0.09 log units) below it; the range from low to high includes it.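

Putting the selenium group in place of cyanosulfanyl gave a 2.2-fold lower number from compound 3 to compound 4 (0.34 log units; beyond the scatter) in this assay on this second core. The two steps agree in direction, and their sizes cannot be told apart: the same change on two cores in this assay, a 3.1-fold lower number (0.49 log units; beyond the scatter) from compound 1 to compound 2 and a 2.2-fold lower number (0.34 log units; beyond the scatter) from compound 3 to compound 4, 1.4-fold (0.16 log units) apart, within the scatter of two such steps.

So in this cell assay the change carried over from the core of compound 1 to the core of compound 3, but two pairs set no rule for other cores and do not show why the number falls.

Still open, going by these compounds, is how the step behaves with a longer chain linking the group to the core. On these data alone, it is also open whether the step holds on a core carrying an amine or a carboxylic acid.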